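Trimming the Sulfone Substituent in a Pyridopyrimidinone Series

The source may hold more compounds than are shown below. What is called first, only, known or untested is meant among the compounds shown, and "the series" means these compounds.

Compound 1, `Cn1c(=O)c(S(=O)(=O)Cc2ccc(F)cc2F)cc2cnc(Nc3ccc4[nH]ccc4c3)nc21`, belongs to a small set of three measured compounds. In a functional assay on K562 cells (Homo sapiens) for inhibition, read by trypan blue exclusion, with a stated time of 72 h (a lower number here means a stronger inhibitor, a higher number a weaker inhibitor), compound 1 gives 1000 nM, the second highest of the three numbers. Its closest neighbour is compound 3, `Cn1c(=O)c(S(=O)(=O)c2ccc(F)cc2F)cc2cnc(Nc3cnc4[nH]ccc4c3)nc21`, which in this assay gives 750 nM; the two values lie within the usual scatter, so nothing separates them. Compound 2, `O=c1c(S(=O)(=O)c2ccc(F)cc2F)cc2cnc(Nc3ccc4[nH]ccc4c3)nc2n1CC1CCCC1`, stands furthest away: in this assay compound 2 gives 7000 nM, a weaker result that lies clearly beyond the scatter relative to compound 1.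

The next compound, compound 4, `Cn1c(=O)c(S(=O)(=O)c2ccc(F)cc2)cc2cnc(Nc3ccc4[nH]ccc4c3)nc21`, differs from compound 1 in one place: 4-fluorophenyl in place of 2,4-difluorobenzyl on a sulfonyl sulfur. The group on the sulfonyl sulfur loses its benzyl linkage and one of its two fluorine atoms, leaving a 4-fluorophenyl ring attached to the sulfonyl sulfur whose other neighbour is an aromatic carbon.

Going by the values given here, no measured pair in this set shares exactly this change, so any step can only be read off compound 1 and the spread of the other two. Compound 4 is expected to land close to compound 1, with at most a modest step and most likely none beyond the scatter, as the step of a 1.4-fold lower number from compound 1 to compound 4 (0.15 log units; within the scatter) implies. The estimate for compound 4 in this assay is 700 nM, with a range from 250 nM to 2000 nM.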

Compound 4, half-maximal inhibitory concentration: 200 nM
For compound 4 the middle estimate is 3.5-fold (0.54 log units) above the measured one, outside the stated range (below it).
By their numbers in this assay, from the lowest: compound 4; then compounds 3 and 1 (each within the scatter of the next); then compound 2.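

In this assay, going by these compounds alone, replacing 2,4-difluorobenzyl with 4-fluorophenyl on a sulfonyl sulfur gives a 5.0-fold lower number from compound 1 to compound 4 (0.70 log units; beyond the scatter), the only step in this set between compounds that differ in one place. It shows that the result at this position depends on the group the sulfonyl sulfur carries, and that the shorter group with fewer heavy atoms, 7 against 9, goes with the stronger result here. Both groups keep one six-membered aromatic ring of carbon only and have no hydrogen-bond donors or acceptors, and nothing given here explains the step.

This single step combines two alterations, the loss of the benzyl linkage and the loss of one fluorine atom, so it cannot say which of them matters; a 4-fluorobenzyl or a plain phenyl group on the same sulfonyl sulfur would be needed to separate them. From the compounds shown here alone, it is also open whether the trend continues beyond aromatic groups, for instance with a methyl or cyclopropyl group in that place, and compounds 2 and 3 differ from compound 4 in more than one place, so they cannot settle this.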